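The compounds below may be only part of what the source reports. "The series", "measured", "known", "first", "only" and "open" are said of these compounds alone.

Working notes on the series. All values are from a functional assay on MC-38 cells (Mus musculus) for antiproliferative activity, read by CCK-8 assay, with a stated time of 48 h; a higher number here means a weaker inhibitor, a lower number a stronger inhibitor.

compound 1 `COc1ccc(/C=C\c2cc(OC)c(OC)c(OC)c2)cc1OCc1ccc(CN2CC[C@@H](O)C2)cc1`: 6900 nM
compound 2 `COc1ccc(/C=C\c2cc(OC)c(OC)c(OC)c2)cc1OCc1ccc(C=O)cc1`: 900 nM
compound 3 `COc1ccc(/C=C\c2cc(OC)c(OC)c(OC)c2)cc1OCc1ccc(CN[C@H](C(=O)O)[C@@H](C)O)cc1`: a limit, > 10000 nM

Among the two plain numbers, compound 1 gives the highest. Compound 3 sits at the limit of > 10000 nM in this assay, at which 1 of the 3 values shown sits, and so supplies only a floor, not a number. The measured range is framed by a 7.7-fold lower number from compound 1 to compound 2 (0.88 log units; beyond the scatter) and by an at least 11-fold higher number from compound 2 to compound 3 (1.04 log units; beyond the scatter); the step of an at least 1.4-fold higher number from compound 1 to compound 3 (0.16 log units; that floor lies within the scatter) cannot be sized beyond its floor.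

Compound 4 `COc1ccc(/C=C\c2cc(OC)c(OC)c(OC)c2)cc1OCc1ccc(CO)cc1` differs from compound 1 by hydroxy in place of 3-hydroxypyrrolidin-1-yl on a saturated chain carbon bound to an aromatic carbon. The step that bears most directly on it is a 7.7-fold lower number from compound 1 to compound 2 (0.88 log units; beyond the scatter), where the same (3-hydroxypyrrolidin-1-yl)methyl was replaced by formyl and the number fell. The limit of compound 3 shows that a larger ((1-carboxy-2-hydroxypropyl)amino)methyl in that place gives no gain. Hydroxymethyl is closer in size to formyl than to either amine-bearing group, so a lower number than compound 1 is expected, though perhaps not the full drop seen with compound 2. The expected step is a 3.5-fold lower number from compound 1 to compound 4 (0.54 log units; beyond the scatter). Compound 4 is estimated at 2000 nM, with a range of 700 nM to 6000 nM.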

Compound 4, half-maximal inhibitory concentration: 5700 nM
Beside the measured number, compound 4's estimate is 2.9-fold (0.45 log units) below it; measured number inside the range.
By their numbers in this assay, from the lowest: compound 2; then compounds 4 and 1 (each within the scatter of the next). At a limit, above all of these: compound 3.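

In this assay, hydroxy in place of 3-hydroxypyrrolidin-1-yl on a saturated chain carbon bound to an aromatic carbon gives a 1.2-fold lower number from compound 1 to compound 4 (0.08 log units; within the scatter); loss of the 3-hydroxypyrrolidin-1-yl alone therefore does not reproduce a 7.7-fold lower number from compound 1 to compound 2 (0.88 log units; beyond the scatter), the step to formyl. Hydroxymethyl in place of formyl gives a 6.3-fold higher number from compound 2 to compound 4 (0.80 log units; beyond the scatter), which ties the lower number in this set to formyl itself, with compounds 1 and 4 alike carrying a saturated carbon at that place. Compound 3 stands at a limit, and an at least 1.7-fold lower number from compound 3 to compound 4 (0.24 log units; that floor lies within the scatter) cannot be read beyond its floor: the limit of > 10000 nM in this assay, at which 1 of the 4 values shown sits.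

Open, from the compounds shown here alone, is whether the number of compound 2 depends on the formyl carbonyl as such, which a nitrile, an acetyl or a methyl ester on that aromatic carbon would test. Also open, going by these compounds, is how a plain aminomethyl group compares with hydroxymethyl at this place.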